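Azepan-1-yl for diethylamino on the sulfonyl sulfur

The compounds below may be only part of what the source reports. "The series", "measured", "known", "first", "only" and "open" are said of these compounds alone.

Among the compounds with values here, in a functional assay on SK-MEL-5 cells (Homo sapiens) for inhibition, with a stated time of 72 h (on this read-out higher numbers stand for weaker inhibition of growth and lower numbers for stronger inhibition of growth), compound 1 (`CCN(CC)S(=O)(=O)c1ccc(OC)c(NC(=O)c2[nH]c(C)c3c2CCCCC3=O)c1`) gives 16300 nM as the only exact number so far. Compound 2 (`CCN(CC)S(=O)(=O)c1ccc(O)c(NC(=O)c2[nH]c(C)c3c2CCCCC3=O)c1`) reads > 80000 nM in this assay and this is a limit of the assay. Within the data shown here, the one measured step runs an at least 4.9-fold higher number from compound 1 to compound 2 (0.69 log units; beyond the scatter) and involves hydrogen in place of methyl on an oxygen on an aromatic ring, so it does not touch the sulfonyl sulfur. Compound 3 (`COc1ccc(S(=O)(=O)N2CCCCCC2)cc1NC(=O)c1[nH]c(C)c2c1CCCCC2=O`) carries azepan-1-yl in place of diethylamino on a sulfonyl sulfur with azepan-1-yl in place of diethylamino on a sulfonyl sulfur. In this assay compound 1 stands at 16300 nM. Among the measured compounds shown here, no measured step bears on this change, so no shift beyond the scatter is expected from compound 1 in this read-out. The expected step is a 1.2-fold lower number from compound 1 to compound 3 (0.07 log units; within the scatter) and no more. For compound 3 the estimate is 14000 nM with an expected range from 6000 nM to 40000 nM in this assay.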

Compound 3, concentration for 50% growth inhibition: 6850 nM
Compound 3: middle estimate off by 2.0-fold (0.31 log units), on the high side; the range from low to high includes it.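

In this assay, azepan-1-yl in place of diethylamino on the sulfonyl sulfur gives a 2.4-fold lower number from compound 1 to compound 3 (0.38 log units; beyond the scatter), so a change at this place can move the read-out beyond the scatter. Within the data shown here, the earlier step concerned only an oxygen on an aromatic ring, which makes this the first reading at the sulfonyl sulfur, and it runs toward stronger inhibition of growth. Nothing measured here accounts for this shift. On these data alone, whether the seven-membered ring itself is needed remains open, as a piperidine or morpholine on the sulfonyl sulfur would show.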